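A few compounds are considered here, and "the series" means these few. Any claim that something is new, unique, unknown or untested is made for them only; others in the source may bear on it.

Compound 1 `Cc1ccc(NC(=S)NC(=O)c2ccc(OCc3ccccc3)cc2)cc1-c1nc2ccccc2[nH]1`, compound 2 `Cc1ccc(NC(=S)NC(=O)c2ccc(OCc3cccc(Cl)c3)cc2)cc1-c1nc2ccccc2[nH]1` and compound 3 `Cc1ccc(NC(=S)NC(=O)c2ccc(OCc3ccccc3F)cc2)cc1-c1nc2ccccc2[nH]1` share one core and differ only in the group on the saturated chain carbon bound to an oxygen on an aromatic ring. In a functional assay on HT-29 cells (Homo sapiens) for inhibition, read by MTT assay, with a stated time of 48 h (on this read-out higher numbers stand for weaker inhibition and lower numbers for stronger inhibition), compound 1 gives 28800 nM, compound 2 gives 35300 nM and compound 3 gives 1870 nM. Compound 2 thus shows the highest number of the three, though a 1.2-fold higher number from compound 1 to compound 2 (0.09 log units; within the scatter), whereas a 19-fold lower number from compound 2 to compound 3 (1.28 log units; beyond the scatter). Compound 4 `Cc1ccc(NC(=S)NC(=O)c2ccc(OCc3ccc(Cl)cc3Cl)cc2)cc1-c1nc2ccccc2[nH]1` carries 2,4-dichlorophenyl in place of 3-chlorophenyl on a saturated chain carbon bound to an oxygen on an aromatic ring. The large steps of a 15-fold lower number from compound 1 to compound 3 (1.19 log units; beyond the scatter) and a 19-fold lower number from compound 2 to compound 3 (1.28 log units; beyond the scatter) both concern 2-fluorophenyl, while chloro alone hardly moved the number in a 1.2-fold higher number from compound 1 to compound 2 (0.09 log units; within the scatter). Because a 19-fold lower number from compound 2 to compound 3 (1.28 log units; beyond the scatter), a lowering is expected, but since chlorine replaces fluorine here the expected step of a 3.5-fold lower number from compound 2 to compound 4 (0.55 log units; beyond the scatter) is kept moderate. Compound 4 is estimated at 10000 nM, between 2500 nM and 40000 nM.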

Compound 4, half-maximal inhibitory concentration: 11600 nM
For compound 4 the middle estimate is 1.2-fold (0.06 log units) below the measured one, within the range that was stated.
By their numbers in this assay, from the lowest: compound 3; then compound 4; then compounds 1 and 2 (each within the scatter of the next).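

In this assay, going by these compounds alone, this position responds to chlorine after all: 2,4-dichlorophenyl lowers the number (a 2.5-fold lower number from compound 1 to compound 4 (0.39 log units; beyond the scatter)) and (a 3.0-fold lower number from compound 2 to compound 4 (0.48 log units; beyond the scatter)), whereas the single chlorine of compound 2 left it within the scatter of compound 1. Even so, 2-fluorophenyl remains clearly better, since moving away from it raises the number (a 6.2-fold higher number from compound 3 to compound 4 (0.79 log units; beyond the scatter)). Nothing measured here explains these differences.

The compounds shown leave open how a methoxy group or an amine on this phenyl ring would behave. They also leave open the effect of a longer chain between the oxygen and the ring.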